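The compounds below may be only part of what the source reports. "The series", "measured", "known", "first", "only" and "open" are said of these compounds alone.

Working notes on the series. All three measured compounds share one core and differ only in the group on an aromatic carbon of a six-membered aromatic ring with 1 nitrogen. Compound 1 `C[C@H](NC(=O)c1cc(C(F)(F)F)nn1C)c1nc(-c2ccnc(N(C)C)c2)no1` carries dimethylamino there; in an assay on T-REx-293 cells for inhibition of potassium channel subfamily T member 1 (Homo sapiens), read by patch clamp (on this read-out higher numbers stand for weaker inhibition and lower numbers for stronger inhibition), compound 1 gives 454 nM. Compound 2 `C[C@H](NC(=O)c1cc(C(F)(F)F)nn1C)c1nc(-c2ccnc(C3CC3)c2)no1` carries cyclopropyl, and in this assay compound 2 gives 16 nM. Compound 3 `C[C@H](NC(=O)c1cc(C(F)(F)F)nn1C)c1nc(-c2ccnc(C(F)F)c2)no1` carries difluoromethyl, and in this assay compound 3 gives 61 nM. Of the three numbers compound 3 stands second highest: a 3.8-fold higher number from compound 2 to compound 3 (0.58 log units; beyond the scatter), whereas a 7.4-fold lower number from compound 1 to compound 3 (0.87 log units; beyond the scatter). The widest step is a 28-fold lower number from compound 1 to compound 2 (1.45 log units; beyond the scatter).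

Compound 4 `CO[C@@H](C)c1cc(-c2noc([C@H](C)NC(=O)c3cc(C(F)(F)F)nn3C)n2)ccn1` differs from compound 3 in one place: 1-methoxyethyl in place of difluoromethyl on an aromatic carbon. Going by the values given here, no measured step swaps difluoromethyl for a group of this kind, so only indirect bearing exists: the three exchanges at this position moved the number by modest to large amounts in both directions, which shows the position is sensitive. With nothing pointing firmly either way, a step of modest size in either direction is expected, most likely staying within the span set by compound 2 and compound 1. Compound 4 is therefore estimated at 45 nM in this assay, with a range from 10 nM to 200 nM. The expected step is a 1.4-fold lower number from compound 3 to compound 4 (0.13 log units; within the scatter).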

Compound 4, half-maximal inhibitory concentration: 744 nM
For compound 4 the middle estimate is 17-fold (1.22 log units) below the measured one, outside the stated range (above it).
By their numbers in this assay, from the lowest: compound 2; then compound 3; then compounds 1 and 4 (each within the scatter of the next).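

In this assay, 1-methoxyethyl in place of difluoromethyl gives a 12-fold higher number from compound 3 to compound 4 (1.09 log units; beyond the scatter), and in place of cyclopropyl gives a 47-fold higher number from compound 2 to compound 4 (1.67 log units; beyond the scatter), so the low numbers at this position are not kept across all non-ring or small groups: a 1-methoxyethyl group with one defined stereocentre, only one heavy atom larger than difluoromethyl by the printed counts, falls far from both compound 2 and compound 3. Dimethylamino no longer stands alone at the high end of the series, since 1-methoxyethyl in place of dimethylamino gives a 1.6-fold higher number from compound 1 to compound 4 (0.21 log units; within the scatter), which places compound 1 and compound 4 level, with cyclopropyl and difluoromethyl the only groups here giving low numbers. No measurement at hand explains why this exchange shifts the number so strongly.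

On these data alone, whether the oxygen or the branched carbon chain of 1-methoxyethyl governs the change stays open, and an isopropyl group and a methoxymethyl group at this place would separate the two. The opposite configuration at the stereocentre of 1-methoxyethyl also leaves open whether the spatial arrangement of this group matters at all.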